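From bromo to trifluoromethyl on the shared core

The source may hold more compounds than are shown below. What is called first, only, known or untested is meant among the compounds shown, and "the series" means these compounds.

In a functional assay on KYSE-410 cells (Homo sapiens) for antiproliferative activity, read by MTT assay, with a stated time of 72 h (on this read-out lower numbers stand for stronger inhibition and higher numbers for weaker inhibition), compound 1 (`O=C(Nc1cc(F)c(F)c(F)c1)c1cc(=O)[nH]c2cc(Br)ccc12`) gives > 20000 nM, which is a limit of the assay and not a number. For the measured compounds named here, compound 2 (`O=C(Nc1cc(F)cc(F)c1)c1cc(=O)[nH]c2cc(Br)ccc12`) gives 11200 nM, the only true number available in this assay. Going by the values given here, the single measured step, an at least 1.7-fold lower number from compound 1 to compound 2 (0.25 log units; that floor lies within the scatter), has a floor that lies within the scatter, and its true size stays open, as the limit of > 20000 nM in this assay, at which 1 of the 2 values shown sits, shows. Compound 3 (`O=C(Nc1cc(F)cc(F)c1)c1cc(=O)[nH]c2cc(C(F)(F)F)ccc12`) carries trifluoromethyl in place of bromo on an aromatic carbon. Among the compounds with values here, no measured step touches this place, so the one step available bears on it only weakly, and no change beyond the scatter is expected in this assay. The expected size is a 1.1-fold lower number from compound 2 to compound 3 (0.05 log units; within the scatter). For compound 3 the estimated value is 10000 nM, with an expected range from 4500 nM to 20000 nM.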

Compound 3, half-maximal inhibitory concentration: 17900 nM
Estimate against measurement, compound 3: 1.8-fold (0.25 log units) below, and the stated range covers the measured number.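

In this assay, for the compounds shown here, the only measured step at this place on the shared core, with trifluoromethyl in place of bromo, gives a 1.6-fold higher number from compound 2 to compound 3 (0.20 log units; within the scatter). Four heavy atoms thus enter where one leaves, on an aromatic carbon of the fused system, with no change that can be told from the scatter, so the two groups cannot be separated in this assay. Compound 1 gives a limit and not a number: the limit of > 20000 nM in this assay, at which 1 of the 3 values shown sits.

Whether this place responds to a different kind of group, such as an amine or a carboxylic acid, stays open, as the two groups shown here are the only ones to have occupied it. From the compounds shown here alone, it is also open whether the same exchange would give a comparable result on the core of compound 1.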